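The source may report more compounds than this note shows. Statements on the series, on what has been measured and on what is new or still open speak of the compounds shown alone.

Measured compounds:
compound 1 `CC(C)(C)OC(=O)NCCCCNC(=O)CN1CN(c2ccccc2)C2(CCN(C(=O)c3ccc(C(C)(C)C)cc3)CC2)C1=O`, "not determined" (no result reported) in an assay on HEK293 cells for displacement of a labelled ligand from NPC1-like intracellular cholesterol transporter 1 (Homo sapiens); a higher number here means a weaker inhibitor, a lower number a stronger inhibitor
compound 2 `CC(C)(C)c1ccc(C(=O)N2CCC3(CC2)C(=O)N(CC(=O)NCN)CN3c2ccccc2)cc1`, 26500 nM
compound 3 `CC(C)(C)OC(=O)NC1CCN(C(=O)CN2CN(c3ccccc3)C3(CCN(C(=O)c4ccc(C5CCCCC5)cc4)CC3)C2=O)CC1`, 4800 nM

Compound 2 holds the highest of the two numbers available, which makes it the weaker of the two measured inhibitors; its nearest neighbour is compound 3, whose lower value lies beyond the scatter of repeated measurements. Compound 1 carries no result. Among the compounds with values here, compounds 2 and 3 differ in more than one place, so no single step between them can be read off, and only their two values can be compared.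

The step from compound 2 to compound 4 `CC(C)(C)c1ccc(C(=O)N2CCC3(CC2)C(=O)N(CC(=O)N2CCC(O)CC2)CN3c2ccccc2)cc1` alters the glycinamide end of the shared core: 4-hydroxypiperidin-1-yl in place of (aminomethyl)amino on a carbonyl carbon. Both compounds keep the same aromatic amide on the other side of the core, so the change is confined to the carbonyl carbon whose other neighbour is a saturated chain carbon.

Within the data shown here, no measured pair isolates this change. Among the measured compounds shown here, compound 3, the only compound with a piperidine on that carbonyl, gives 4800 nM, but it also carries a different aryl substituent, so its lower number cannot be attributed to the piperidine alone. He therefore expects a moderate step toward a lower number, a 2.7-fold lower number from compound 2 to compound 4 (0.42 log units; beyond the scatter), with considerable uncertainty. His estimate for compound 4 is 10000 nM, with a range from 3000 nM to 40000 nM.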

Compound 4, half-maximal inhibitory concentration: 4700 nM
The estimate for compound 4 lay 2.1-fold (0.33 log units) above the measured number, within the range that was stated.
By their numbers in this assay, from the lowest: compounds 4 and 3 (each within the scatter of the next); then compound 2.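

Within the data shown here, replacing (aminomethyl)amino with 4-hydroxypiperidin-1-yl on a carbonyl carbon gives, in this assay, a 5.6-fold lower number from compound 2 to compound 4 (0.75 log units; beyond the scatter) and so provides the first reading of this position with the rest of the molecule held fixed. The step lies beyond the scatter, though it is modest, and it shows that a group with a six-membered non-aromatic ring can stand on this carbonyl carbon while the number falls rather than rises. Nothing available accounts for the step, and this single pair cannot separate the arrival of the ring, the arrival of the hydroxyl or the departure of the (aminomethyl)amino group.

The compounds shown leave open whether the hydroxyl contributes at all, a question that plain piperidin-1-yl, a morpholine or a 4-aminopiperidin-1-yl group on the same carbonyl carbon would address while the aromatic amide stayed unchanged. Among these compounds, they also leave open whether an open chain, such as a longer alkylamine or one ending in a carboxylic acid, would behave like the ring, so the single step gives no trend for this position.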